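Fluoro in place of chloro: notes towards compound 3

The compounds below may be only part of what the source reports. "The series", "measured", "known", "first", "only" and "open" are said of these compounds alone.

Measured so far in an ADME assay on BHK-21 cells (Mesocricetus auratus) for cytotoxicity, read by MTT assay, with a stated time of 72 h; on this read-out lower numbers stand for higher toxicity in this test and higher numbers for lower toxicity in this test
- compound 1 `NS(=O)(=O)c1ccc(N2N=C(c3ccc(OCc4ccccc4)cc3)CC2c2ccccc2Cl)cc1` gives 12000 nM
- compound 2 `NS(=O)(=O)c1ccc(N2N=C(c3ccc(OCc4ccccc4)cc3)CC2c2cccc(Cl)c2)cc1` gives 45000 nM

Of these two, compound 2 stands highest, at 45000 nM. Compound 3 `NS(=O)(=O)c1ccc(N2N=C(c3ccc(OCc4ccccc4)cc3)CC2c2cccc(F)c2)cc1` carries fluoro in place of chloro on an aromatic carbon. For the measured compounds named here, the only measured step, a 3.8-fold higher number from compound 1 to compound 2 (0.57 log units; beyond the scatter), exchanges 2-chlorophenyl for 3-chlorophenyl, so it bears only indirectly. Going by the values given here, no measured step covers a change of halogen, and no shift beyond the scatter is expected in this assay. The expected step is a 1.1-fold higher number from compound 2 to compound 3 (0.03 log units; within the scatter). For compound 3 the estimate is 48000 nM, with an expected range of 20000 nM to 100000 nM.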

Compound 3, half-maximal cytotoxic concentration: 9000 nM
Compound 3: the middle estimate sits 5.3-fold (0.73 log units) above what was measured; measured number outside the range, below it.
By their numbers in this assay, from the lowest: compounds 3 and 1 (each within the scatter of the next); then compound 2.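

In this assay, the halogen on this aromatic carbon counts, not only where it sits: fluoro in place of chloro gives a 5.0-fold lower number from compound 2 to compound 3 (0.70 log units; beyond the scatter) in this series. Exchanging 2-chlorophenyl for 3-fluorophenyl gives a 1.3-fold lower number from compound 1 to compound 3 (0.12 log units; within the scatter), so among these three the high number goes with 3-chlorophenyl alone. No measurement at hand accounts for this step.

On these data alone, whether fluoro in place of chloro gives a similar step from 2-chlorophenyl remains open. So does how 3-bromophenyl or 3-aminophenyl would read in this assay.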